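Cyano in Place of Methylsulfonyl in a Flat Series

This account rests on a few compounds, and the source may have more. Where it says the series, first, only, none or still open, it means among the compounds named here.

In a functional assay on DU-145 cells (Homo sapiens) for inhibition, read by MTT assay, with a stated time of 48 h (a higher number here means a weaker inhibitor, a lower number a stronger inhibitor), compound 1 (`CS(=O)(=O)c1ccc(-c2nc3ccccn3c2Sc2ccccc2)cc1`) gives 67800 nM, compound 2 (`Cc1ccc(-c2nc3ccccn3c2Sc2ccccc2)cc1`) gives 83300 nM and compound 3 (`CSc1ccc(-c2nc3ccccn3c2Sc2ccccc2)cc1`) gives 52100 nM. Compound 1 therefore stands within the scatter of both other compounds. Compound 4 (`N#Cc1ccc(-c2nc3ccccn3c2Sc2ccccc2)cc1`) has cyano in place of methylsulfonyl on an aromatic carbon, para to a large group: cyano in place of methylsulfonyl on an aromatic carbon. Two measured replacements of methylsulfonyl bear on this change: a 1.2-fold higher number from compound 1 to compound 2 (0.09 log units; within the scatter) and a 1.3-fold lower number from compound 1 to compound 3 (0.11 log units; within the scatter). The remaining comparison is a 1.6-fold lower number from compound 2 to compound 3 (0.20 log units; within the scatter). With all three steps inside the scatter, no step beyond the scatter is expected in this assay. For compound 4 the estimated value is 65000 nM, with an expected range from 32000 nM to 125000 nM. The expected step is a 1.0-fold lower number from compound 1 to compound 4 (0.02 log units; within the scatter).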

Compound 4, half-maximal inhibitory concentration: 76500 nM
Estimate against measurement, compound 4: 1.2-fold (0.07 log units) below; low and high end bracket the measured number.
By their numbers in this assay, from the lowest: compounds 3, 1, 4 and 2 (each within the scatter of the next).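

In this assay cyano joins the flat picture at this position, para to a large group: the series shows a 1.1-fold higher number from compound 1 to compound 4 (0.05 log units; within the scatter) along with a 1.5-fold higher number from compound 3 to compound 4 (0.17 log units; within the scatter) and a 1.1-fold lower number from compound 2 to compound 4 (0.04 log units; within the scatter). A triple bond of 2 heavy atoms thus cannot be told apart here from methylsulfonyl, methylsulfanyl or methyl, so all four groups at this place give numbers within the scatter of one another. Nothing available explains this flatness. On these data alone, whether an amine or a carboxylic acid at this position would step beyond the scatter stays open. So does whether any change elsewhere on the shared core would do so.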